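Shortening the alkyl chain on the shared core

The compounds below may be only part of what the source reports. "The series", "measured", "known", "first", "only" and "open" are said of these compounds alone.

Measured so far, in a functional assay on the whole organism for inhibition, with Chlorella vulgaris as the target, read by spectrophotometry, with a stated time of 4 h; a lower number here means a stronger inhibitor, a higher number a weaker inhibitor:
Compound 1 `CCCCc1cnc(C(=O)/C=C/c2ccccc2O)cn1` gives 147000 nM.
Compound 2 `CCCCc1cnc(C(=O)/C=C/c2ccc(O)cc2)cn1` gives 265000 nM.
Compound 3 `CC(C)Cc1cnc(C(=O)/C=C/c2ccc(O)cc2)cn1` gives 232000 nM.

Compound 1 gives the lowest of the three numbers, but its step to each of the other two is within the scatter, so no order among the three can be drawn. The step of a 1.8-fold higher number from compound 1 to compound 2 (0.26 log units; within the scatter) is within the scatter, and so is the step of a 1.1-fold lower number from compound 2 to compound 3 (0.06 log units; within the scatter); neither measured change has moved the read-out beyond what repeated measurements would give.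

Compound 4 `CCCc1cnc(C(=O)/C=C/c2ccccc2O)cn1` differs from compound 1 by hydrogen in place of methyl on a saturated chain carbon, three bonds along the chain from an aromatic carbon. For the measured compounds named here, no measured step shortens or lengthens this saturated chain; the step of a 1.1-fold lower number from compound 2 to compound 3 (0.06 log units; within the scatter) alters only its branching and stays within the scatter, and the step of a 1.8-fold higher number from compound 1 to compound 2 (0.26 log units; within the scatter) concerns the other ring. With nothing in the measured series pointing to a change at this place, no step beyond the scatter is expected for compound 4 in this assay, and the expected step is a 1.1-fold higher number from compound 1 to compound 4 (0.04 log units; within the scatter). Compound 4 is estimated at 160000 nM in this assay, with a range from 80000 nM to 320000 nM.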

Compound 4, half-maximal inhibitory concentration: 100000 nM
Estimate against measurement, compound 4: 1.6-fold (0.20 log units) above; low and high end bracket the measured number.
By their numbers in this assay, from the lowest: compounds 4, 1, 3 and 2 (each within the scatter of the next, the first and the last beyond it).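

Butyl to propyl on the shared core is the first measured change in the length of this saturated chain, and in this assay it gives a 1.5-fold lower number from compound 1 to compound 4 (0.17 log units; within the scatter). For the compounds shown here, the earlier steps touched only the branching of the chain or the hydroxyphenyl ring, so this is the first reading at the chain's far end: with 2-hydroxyphenyl on the core, removing that methyl leaves compound 4 indistinguishable from compound 1. No supporting measurement bears on this result, so it stands as a read-out alone.

Going by these compounds, whether a longer chain such as hexyl, or a chain ending in an amine or a carboxylic acid, would move the read-out beyond the scatter stays open. So does whether the same shortening reads alike with 4-hydroxyphenyl on the core.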